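This account rests on a few compounds, and the source may have more. Where it says the series, first, only, none or still open, it means among the compounds named here.

In a functional assay on PC-3 cells (Homo sapiens) for inhibition, read by sulforhodamine B assay, with a stated time of 72 h (on this read-out higher numbers stand for weaker inhibition and lower numbers for stronger inhibition), three compounds that share one core and differ only in the group on a carbonyl carbon have been measured. Compound 1 `CC1CCN(C(=O)c2c(N)sc(-c3ccc(Cl)cc3)c2-c2ccc(Cl)cc2)CC1`, carrying 4-methylpiperidin-1-yl, gives 5750 nM. Compound 2 `Nc1sc(-c2ccc(Cl)cc2)c(-c2ccc(Cl)cc2)c1C(=O)NC1CCC1`, carrying cyclobutylamino, gives 24800 nM. Compound 3 `Nc1sc(-c2ccc(Cl)cc2)c(-c2ccc(Cl)cc2)c1C(=O)N1CCCC1`, carrying pyrrolidin-1-yl, gives 6220 nM. That places compound 3 level with compound 1, as a 1.1-fold higher number from compound 1 to compound 3 (0.03 log units; within the scatter) shows, and well under compound 2.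

The next compound, compound 4 `Nc1sc(-c2ccc(Cl)cc2)c(-c2ccc(Cl)cc2)c1C(=O)NC1CCCC1`, has cyclopentylamino in place of pyrrolidin-1-yl on a carbonyl carbon.

Among the compounds with values here, two measured steps bear on this change. The closest is a 4.0-fold lower number from compound 2 to compound 3 (0.60 log units; beyond the scatter), which replaces cyclobutylamino with pyrrolidin-1-yl, the reverse kind of exchange. The step of a 4.3-fold higher number from compound 1 to compound 2 (0.63 log units; beyond the scatter) also leads to cyclobutylamino and ends at a higher number. Within the data shown here, compound 2, at 24800 nM, is therefore the best guide, although no compound with cyclopentylamino has been measured and the ring size differs from that in compound 2. A modest move to a higher number, meaning weaker inhibition, is expected. The expected change is a 2.9-fold higher number from compound 3 to compound 4 (0.46 log units; beyond the scatter). Compound 4 is estimated at 18000 nM, with an expected range from 7000 nM to 45000 nM.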

Compound 4, half-maximal inhibitory concentration: 21200 nM
For compound 4 the middle estimate is 1.2-fold (0.07 log units) below the measured one; the measured number falls inside the stated range.
By their numbers in this assay, from the lowest: compounds 1 and 3 (each within the scatter of the next); then compounds 4 and 2 (each within the scatter of the next).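

In this assay, keeping a five-membered ring on the carbonyl carbon does not keep the number: in a 3.4-fold higher number from compound 3 to compound 4 (0.53 log units; beyond the scatter), the nitrogen no longer lies inside the ring and now carries the amide hydrogen. Changing the ring on the amide-type nitrogen makes no readable difference, with cyclopentyl in place of cyclobutyl giving a 1.2-fold lower number from compound 2 to compound 4 (0.07 log units; within the scatter), so the four compounds now fall into two sets: compounds 2 and 4, which have the amide hydrogen, sit at the higher numbers, compounds 1 and 3, which lack it, sit at the lower numbers, as a 3.7-fold higher number from compound 1 to compound 4 (0.57 log units; beyond the scatter) also shows, and no compound shown goes against this. Nothing given here explains why the two sets differ.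

Still open, from the compounds shown here alone, is whether the amide hydrogen or the ring standing outside the nitrogen goes with the higher numbers, since the two change together in these compounds. A methyl(cyclopentyl)amino group, which keeps the cyclopentyl ring but has no amide hydrogen, would pull the two apart, and an open-chain diethylamino group would test whether the pattern holds without a ring.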